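The source may report more compounds than this note shows. Statements on the series, on what has been measured and on what is new or still open speak of the compounds shown alone.

Compound 1 `COc1cc(C)ccc1S(=O)(=O)NC1=NCCN1C(=S)SN1CCn2c1nsc2=S`, compound 2 `COc1cccc(S(=O)(=O)NC2=NCCN2C(=S)SN2CCn3c2nsc3=S)c1` and compound 3 `COc1ccc(S(=O)(=O)NC2=NCCN2C(=S)SN2CCn3c2nsc3=S)cc1OC` share one core and differ only in the aryl group attached to the sulfonyl sulfur. In a functional assay on KYSE-510 cells (Homo sapiens) for antiproliferative activity, read by crystal violet staining, with a stated time of 96 h (a lower number here means a stronger inhibitor of growth, a higher number a weaker inhibitor of growth), compound 1 gives >= 20000 nM, which is a limit of the assay and not a number. Compound 2 gives >= 20000 nM, again a limit. Compound 3 gives >= 20000 nM, likewise a limit rather than a measured value. Within the data shown here, compound 3 therefore stands where every value so far stands, at the limit of >= 20000 nM in this assay, at which 3 of the 3 values shown sit, and the steps a step that the two limits leave unreadable from compound 1 to compound 2, a step that the two limits leave unreadable from compound 1 to compound 3 and a step that the two limits leave unreadable from compound 2 to compound 3 cannot be given a size or a direction.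

Compound 4 `CC(=O)Nc1ccc(S(=O)(=O)NC2=NCCN2C(=S)SN2CCn3c2nsc3=S)cc1` is the next compound to be tested in this assay. The change from compound 3 is 4-acetamidophenyl in place of 3,4-dimethoxyphenyl on a sulfonyl sulfur. All three measured steps bear on a change of the aryl group at this place, yet none of them is readable, so they give no expected size and no direction for this new step. Because the limit of >= 20000 nM in this assay, at which 3 of the 3 values shown sit, holds for all three compounds, the most likely outcome for compound 4 is again a limit. Compound 4 is expected to give 30000 nM, within a range from 12000 nM to 80000 nM. The expected step is a step that the limit leaves unreadable from compound 3 to compound 4.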

Compound 4, concentration for 50% growth inhibition: >= 20000 nM
Compound 4: no number, only a limit (the forecaster's own chance of this, stated with the estimate: 80%); the middle value is on the limit's open side.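

Compound 4 also gives a limit and not a number, so no step between it and compound 1, compound 2 or compound 3 can be read, in size or in direction: the limit of >= 20000 nM in this assay, at which 4 of the 4 values shown sit.

The compounds shown leave open whether any aryl group on the sulfonyl sulfur of the shared core can give a measurable value in this assay at all.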